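Methylating the phenol of an allylphenol biphenyl

This account rests on a few compounds, and the source may have more. Where it says the series, first, only, none or still open, it means among the compounds named here.

Two measured compounds open this comparison. Compound 1 `C=CCc1cc(-c2ccc(OC)cc2)cc(CC=C)c1O` carries a methoxy-bearing aryl ring and two allyl chains. Compound 1 reached only the limit of a functional assay on HUVEC cells (Homo sapiens) for antiproliferative activity, read by MTT assay, with a stated time of 24 h (a lower number here means a stronger inhibitor, a higher number a weaker inhibitor), where its value is recorded as > 100000 nM; that is a limit of the assay, not a number. Compound 2 `C=CCc1cc(-c2ccc(C(F)(F)F)cc2)ccc1O` carries a trifluoromethyl-bearing aryl ring and one allyl chain. In this assay compound 2 gives 74000 nM. For the measured compounds named here, compound 2 therefore stands as the only compound here with a measured number, while the other value shown sits at the limit (the limit of > 100000 nM in this assay, at which 1 of the 2 values shown sits).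

The step of interest leads to compound 3 `C=CCc1cc(-c2ccc(C(F)(F)F)cc2)ccc1OC`, which is not yet measured. It differs from compound 2 as follows: methyl in place of hydrogen on an oxygen on an aromatic ring. Going by the values given here, no measured pair shows this change, so no reference step exists.

The expectation is that the change from compound 2 to compound 3 moves potency in this assay little beyond the scatter, if at all, and if anything toward a weaker inhibitor, a step estimated as a 1.4-fold higher number from compound 2 to compound 3 (0.13 log units; within the scatter). The value estimated for compound 3 is 100000 nM, with a range from 40000 nM to 300000 nM, carrying a real chance of landing at the assay limit.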

Compound 3, half-maximal inhibitory concentration: > 100000 nM
Compound 3: only a limit was reported (the forecaster's own chance of this, stated with the estimate: 50%); the middle value sits exactly at the limit.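

For the compounds shown here, this is the first direct reading of hydroxy to methoxy, on an oxygen on an aromatic ring, and in this assay the change gives an at least 1.3-fold higher number from compound 2 to compound 3 (0.13 log units; that floor lies within the scatter). Only a floor is known, and because that floor lies within the usual scatter, the step may be negligible or much larger, so the result cannot show whether methyl in place of hydrogen costs any potency. What it does show is that compound 3 gives no number in this assay, leaving compound 2 as the only compound shown with one, and this limit is shared by most of the set: the limit of > 100000 nM in this assay, at which 2 of the 3 values shown sit.

On these data alone, the size of the step therefore stays open, and so does the question of what this oxygen tolerates. An ethyl group on the same oxygen, or an amine or a carboxylic acid in place of the hydroxy, would test whether any other group here can give a number in this assay, and a compound reading well clear of the limit would be needed to give this position a true measured step.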